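Swapping ethyl for tert-butyl on an anti-inflammatory scaffold

The source may report more compounds than this note shows. Statements on the series, on what has been measured and on what is new or still open speak of the compounds shown alone.

Compound 1 `CCc1ccc(C2=NN(c3ccc(S(C)(=O)=O)cc3)C(=O)CC2)cc1` is tested in a functional assay on the whole organism (strain Wistar) for inhibition, with Rattus norvegicus as the target, read by paw edema, with stated times of 30 min and 3 h, at a dose of 0.05 mmol/kg by the oral route (a lower number here means less inhibition, a higher number more inhibition at the dose given (going by the name of the read-out)), where compound 1 gives 46.7%. Its companion, compound 2 `CS(=O)(=O)c1ccc(N2N=C(c3ccc(Cl)c(Cl)c3)CCC2=O)cc1`, gives 26.6%. Between the two, compound 1 stands highest: the step of a number 20.1 percentage points lower from compound 1 to compound 2 (beyond the scatter) comes with 3,4-dichlorophenyl in place of 4-ethylphenyl on a carbon with a double bond to nitrogen.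

Compound 3 `CC(C)(C)c1ccc(C2=NN(c3ccc(S(C)(=O)=O)cc3)C(=O)CC2)cc1` is not yet measured. It differs from compound 1 by tert-butyl in place of ethyl on an aromatic carbon. For the measured compounds named here, the only measured step exchanges the whole aromatic group, while this change keeps the aromatic ring and alters just the alkyl chain on it, so that step bears on the question only loosely. With nothing closer to rest on, the expectation is a change of a number 1.7 percentage points lower from compound 1 to compound 3 (within the scatter), within the scatter. Compound 3 is therefore estimated at 45%, in a range from 30% to 60%.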

Compound 3, a percentage reported as inhibition, in the whole organism at one dose (the size of the read-out at that dose, not a potency): 50%
For compound 3 the middle estimate is 5 percentage points below the measured one, and the stated range covers the measured number.
By their numbers in this assay, from the lowest: compound 2; then compounds 1 and 3 (each within the scatter of the next).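

In this assay, replacing ethyl with tert-butyl gives a number 3.3 percentage points higher from compound 1 to compound 3 (within the scatter), so on this aromatic carbon, para to a large group, these two alkyl groups cannot be told apart. For the compounds shown here, the earlier step, a number 20.1 percentage points lower from compound 1 to compound 2 (beyond the scatter), exchanged the whole substituted aromatic group, so it could not show what the alkyl group alone does; here the aromatic ring stays and only that group differs. Nothing available explains why the two alkyl groups give readings within the scatter of each other.

The compounds shown leave open whether the same holds for a group that is not a plain short alkyl group, such as an amine, a carboxylic acid or a longer chain. They also leave open whether a single chlorine in place of ethyl would be enough to bring the reading down towards that of compound 2.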